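Series notes: the step from compound 3 to compound 4

The source may hold more compounds than are shown below. What is called first, only, known or untested is meant among the compounds shown, and "the series" means these compounds.

Of the compounds shown here, three of the shared core have been measured in an assay on HEK293 cells for inhibition of Toll-like receptor 8 (Homo sapiens), with a stated time of 16 h; a lower number here means a stronger inhibitor, a higher number a weaker inhibitor. Compound 1 `O=C(Nc1ccc(Oc2cccc(C(F)(F)F)c2)cc1)c1c(F)cccc1Cl` gives 2410 nM in this assay. Compound 2 `O=C(Nc1ccc(Oc2cc(F)cc(C(F)(F)F)c2)cc1)c1c(F)cccc1Cl` gives 1590 nM in this assay. Compound 3 `O=C(Nc1ccc(Oc2cc(Cl)cc(C(F)(F)F)c2)cc1)c1c(F)cccc1Cl` gives 2040 nM in this assay. Among the three numbers compound 3 stands second highest, and it lies within the scatter of both others: a 1.2-fold lower number from compound 1 to compound 3 (0.07 log units; within the scatter), and a 1.3-fold higher number from compound 2 to compound 3 (0.11 log units; within the scatter). The remaining step, a 1.5-fold lower number from compound 1 to compound 2 (0.18 log units; within the scatter), is likewise within the scatter, so the three measured compounds cannot be placed in any order.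

Compound 4 `O=C(Nc1ccc(Oc2cc(Br)cc(C(F)(F)F)c2)cc1)c1c(F)cccc1Cl` is not yet measured in this assay. It differs from compound 3 in one place: bromo in place of chloro on an aromatic carbon. The measured steps that bear on this change are those in which the group on that aromatic carbon was exchanged, namely a 1.2-fold lower number from compound 1 to compound 3 (0.07 log units; within the scatter) and a 1.3-fold higher number from compound 2 to compound 3 (0.11 log units; within the scatter); neither reached beyond the scatter. Among the compounds with values here, no larger step is therefore expected for the exchange of chloro for bromo, and the step from compound 3 to compound 4 in this assay is expected to be a 1.0-fold lower number from compound 3 to compound 4 (0.01 log units; within the scatter), none beyond the scatter. Compound 4 is estimated at 2000 nM in this assay, with a range from 900 nM to 4500 nM.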

Compound 4, half-maximal inhibitory concentration: 2320 nM
For compound 4 the middle estimate is 1.2-fold (0.06 log units) below the measured one; low and high end bracket the measured number.
By their numbers in this assay, from the lowest: compounds 2, 3, 4 and 1 (each within the scatter of the next).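

Bromo on this aromatic carbon, meta to a trifluoromethyl group, adds a fourth group to the comparison in this assay and brings three new steps: a 1.1-fold higher number from compound 3 to compound 4 (0.06 log units; within the scatter) and a 1.5-fold higher number from compound 2 to compound 4 (0.16 log units; within the scatter) and a 1.0-fold lower number from compound 1 to compound 4 (0.02 log units; within the scatter) are all small. Hydrogen, fluoro, chloro and bromo at this position therefore give numbers that cannot be placed in order, whereas the earlier compounds showed this only for hydrogen, fluoro and chloro. Nothing available here accounts for this absence of a readable difference.

Going by these compounds, what remains open is whether any group on this carbon can move the number beyond the scatter, for instance a nitrile, an amine, a carboxylic acid or a methoxy group. Also open, on these data alone, is whether the same four groups stay within the scatter of one another when the trifluoromethyl group gives way to another group or when another part of the shared core is changed.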